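The compounds below may be only part of what the source reports. "The series", "measured", "known", "first", "only" and "open" are said of these compounds alone.

In a functional assay on ECa-109 cells (Homo sapiens) for cytotoxicity, read by MTT assay, with a stated time of 72 h (a lower number here means a stronger inhibitor, a higher number a weaker inhibitor), compound 1 `COc1cccc(C=C2C(=O)N(c3ccc(Cl)cc3)N(c3ccc(Cl)cc3)C2=O)c1O` gives 39000 nM. In this assay compound 2 `COc1ccc(C=C2C(=O)N(c3ccc(Cl)cc3)N(c3ccc(Cl)cc3)C2=O)cc1` reaches only the assay limit, > 128000 nM.

Compound 2 therefore stands at a limit, not a number, as the limit of > 128000 nM in this assay, at which 1 of the 2 values shown sits, records. Among the measured compounds shown here, the one measured step that bears on the next change is an at least 3.2-fold higher number from compound 1 to compound 2 (0.51 log units; beyond the scatter), which carried the series from a number to that limit. Compound 3 `O=C1C(=Cc2ccc(F)cc2F)C(=O)N(c2ccc(Cl)cc2)N1c1ccc(Cl)cc1` differs from compound 2 by 2,4-difluorophenyl in place of 4-methoxyphenyl on a double-bonded chain carbon bound to a double-bonded ring carbon. For the measured compounds named here, no measured step tests this change, so no step beyond the scatter is expected: an at least 1.1-fold lower number from compound 2 to compound 3 (0.06 log units; that floor lies within the scatter). Compound 3 is estimated at 110000 nM, with a range from 30000 nM to 400000 nM.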

Compound 3, half-maximal inhibitory concentration: 13100 nM
Estimate against measurement, compound 3: 8.4-fold (0.92 log units) above; the measured number lies below the stated range.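

The place on the double-bonded chain carbon can lower the number as well as raise it: 2,4-difluorophenyl in place of 4-methoxyphenyl gives an at least 9.7-fold lower number from compound 2 to compound 3 (0.98 log units; beyond the scatter). That step is only a floor, and compound 2 stands at a limit, not a number: the limit of > 128000 nM in this assay, at which 1 of the 3 values shown sits.

Against the hydroxy-bearing group, the same change gives a 3.0-fold lower number from compound 1 to compound 3 (0.47 log units; beyond the scatter), so compound 3 holds the lowest number of the three without the hydroxy group of compound 1. Still open, going by these compounds, is how a single fluorine, a chlorine or an amine on this phenyl ring would compare.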